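The compounds below may be only part of what the source reports. "The series", "measured", "known", "first", "only" and "open" are said of these compounds alone.

Of the compounds shown here, three have so far been tested in a functional assay on BGC-823 cells (Homo sapiens) for antiproliferative activity, read by MTT assay, tested at 1 uM; on this read-out higher numbers stand for a stronger effect at the one concentration tested and lower numbers for a weaker effect. Compound 1 `COc1cc(C(=O)N/N=C/c2ccc(F)c(F)c2)cc(OC)c1OC` gives 33.1% in this assay. Compound 2 `COc1ccc(/C=N/NC(=O)c2cc(OC)c(OC)c(OC)c2)c(OC)c1` gives -6.9%. Compound 3 `COc1cc(C2=NN(C(C)=O)C(c3c(Cl)cccc3Cl)O2)cc(OC)c1OC` gives -1.4%. Among these three numbers compound 3 stands second highest; its nearest neighbour is compound 2, whose value lies a little lower but within the usual scatter of repeated measurements, so the two cannot be told apart, while compound 1 lies furthest away, higher by more than that scatter.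

Compound 4 `COc1cc(C2=NN(C(C)=O)C(c3cc(Cl)cc(Cl)c3)O2)cc(OC)c1OC` has not yet been measured. It keeps every atom of compound 3 but joins them differently: 3,5-dichlorophenyl in place of 2,6-dichlorophenyl on a saturated ring carbon The two chlorines stay on the same aromatic ring; only their positions on it differ. Within the data shown here, no pair of measured compounds differs in just one place, so no step of this kind is known from these data, and the outcome for compound 4 can only be judged from compound 3 itself. The expected step of a number 4.4 percentage points higher from compound 3 to compound 4 (within the scatter) is small, most likely within the scatter, with no clear direction. Compound 4 is therefore estimated at 3%, within a range from -15% to 25%, and the measurement will show whether the rearrangement matters.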

Compound 4, a percentage reported as inhibition, at one concentration (the size of the read-out at that concentration, not a potency): 0%
The estimate for compound 4 lay 3 percentage points above the measured number; low and high end bracket the measured number.
By their numbers in this assay, from the lowest: compounds 2, 3 and 4 (each within the scatter of the next); then compound 1.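

Among these compounds, the first comparison between two compounds that differ in only one place concerns the aromatic ring on the saturated ring carbon: in this assay, replacing 2,6-dichlorophenyl with 3,5-dichlorophenyl gives a number 1.4 percentage points higher from compound 3 to compound 4 (within the scatter) for this change. The two groups have the same atoms and the same counts, so this pair isolates where the two chlorines sit on that ring, and for these two arrangements the shift cannot be told apart from ordinary repeat-to-repeat variation. At the one concentration tested, this measurement therefore shows no sensitivity to moving the chlorines between these two arrangements, although that finding rests on a single pair and nothing measured here bears on why the two compounds read alike.

On these data alone, what remains open is whether a different kind of group on this aromatic ring, such as an amine, a carboxylic acid or a hydroxyl group, would produce a step beyond the scatter rather than another one within it. It is also unknown whether the same two chlorine arrangements would still read alike at other concentrations, or if the acetyl group on the neighbouring ring atom gave way to a longer chain.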